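Dropping the bromo group from compound 2

A few compounds are considered here, and "the series" means these few. Any claim that something is new, unique, unknown or untested is made for them only; others in the source may bear on it.

Compound 1 `O=C(CSc1nncnc1-c1cccc2ccccc12)Nc1ccccc1[N+](=O)[O-]` gives 142000 nM
Compound 2 `O=C(CSc1nncnc1-c1ccccc1Cl)Nc1ccccc1Br` gives 73000 nM
Compound 3 `O=C(CSc1nncnc1-c1cccc2ccccc12)Nc1ccc(Cl)cc1Cl` gives 254000 nM

In an ADME assay on MT4 cells (Homo sapiens) for cytotoxicity, read by MTT assay (on this read-out lower numbers stand for higher toxicity in this test and higher numbers for lower toxicity in this test), compound 2 (73000 nM) cannot be told apart from compound 1, while compound 3 stands higher than compound 2 by more than the scatter. Compound 4 `O=C(CSc1nncnc1-c1ccccc1Cl)Nc1ccccc1` has not been measured. Its difference from compound 2 is this: hydrogen in place of bromo on an aromatic carbon (hydrogen in place of bromo on an aromatic carbon, 2-bromophenyl to phenyl).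

One measured step changes the group on the amide-type nitrogen while all else stays fixed: a 1.8-fold higher number from compound 1 to compound 3 (0.25 log units; within the scatter) (2,4-dichlorophenyl in place of 2-nitrophenyl). It stays within the scatter. Within the data shown here, that step swaps one substituted group for another, and no measured compound carries plain phenyl there, so the data show no direction for this change. The expectation in this assay is therefore no step beyond the scatter, and the estimated step is a 1.2-fold higher number from compound 2 to compound 4 (0.07 log units; within the scatter) for now. For compound 4 the estimated value is 85000 nM (expected range 35000 nM to 200000 nM).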

Compound 4, half-maximal cytotoxic concentration: 127000 nM
Estimate against measurement, compound 4: 1.5-fold (0.17 log units) below; the range from low to high includes it.
By their numbers in this assay, from the lowest: compounds 2, 4, 1 and 3 (each within the scatter of the next, the first and the last beyond it).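

In this assay, among these compounds, this is the first reading of plain phenyl on the amide-type nitrogen, and the change from 2-bromophenyl to phenyl gives a 1.7-fold higher number from compound 2 to compound 4 (0.24 log units; within the scatter). Unlike the earlier step, which swapped one substituted group for another, this one removes the substituent outright, and the bromo group on this aromatic carbon can go without a step beyond the scatter, so no direction can be claimed for this change. No measured property or other supporting information bears on this result.

From the compounds shown here alone, it remains open whether an amine or a carboxylic acid on this aromatic carbon would give a step beyond the scatter. Also open, going by these compounds, is how plain phenyl on the amide-type nitrogen would read alongside the other aromatic group carried by compound 1.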